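This account rests on a few compounds, and the source may have more. Where it says the series, first, only, none or still open, it means among the compounds named here.

Measured so far:
compound 1 `O=C1CSC(=O)N1C[C@H]1CN(c2ccc(-n3cc(-c4ccccn4)cn3)c(F)c2)C(=O)O1` — 2.18
compound 2 `O=C1O[C@@H](Cn2ccnn2)CN1c1ccc(-n2cc(-c3ccccn3)cn2)c(F)c1` — 2
compound 3 `CN(C)S(=O)(=O)NC[C@H]1CN(c2ccc(-n3cc(-c4ccccn4)cn3)c(F)c2)C(=O)O1` — 1.38

In a physicochemical assay for lipophilicity, read by HPLC, measured as octanol-water partition (on this read-out lower numbers stand for lower lipophilicity and higher numbers for higher lipophilicity), compound 1 stands highest of the three numbers shown. Its nearest neighbour is compound 2, with a number 0.18 log units lower from compound 1 to compound 2 (within the scatter), a difference that does not rise above the scatter; its furthest is compound 3, with a number 0.80 log units lower from compound 1 to compound 3 (beyond the scatter). Between the other two, a number 0.62 log units lower from compound 2 to compound 3 (beyond the scatter).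

The unmeasured compound 4 `CNC(=O)[C@H]1CN(c2ccc(-n3cc(-c4ccccn4)cn3)c(F)c2)C(=O)O1` differs from compound 1 in one place: methylcarbamoyl in place of (2,4-dioxo-1,3-thiazolidin-3-yl)methyl on a saturated ring carbon. For the measured compounds named here, none of the measured steps repeats this change exactly, since each of them swaps a group on the saturated chain carbon while keeping that carbon in place. Still, both earlier replacements of the 2,4-dioxo-1,3-thiazolidin-3-yl group point downward, one within the scatter and one modestly beyond it, and the entering methylcarbamoyl group brings a hydrogen-bond donor, as the (dimethylsulfamoyl)amino group of compound 3 does. Compound 4 is therefore expected to sit below compound 1 in this assay, with a step of about a number 0.78 log units lower from compound 1 to compound 4 (beyond the scatter). The estimate for compound 4 is 1.4, expected to fall between 0.9 and 1.9.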

Compound 4, partition coefficient: 1.39
Compound 4: middle estimate off by 0.01 log units, on the high side, within the range that was stated.
By their numbers in this assay, from the lowest: compounds 3 and 4 (each within the scatter of the next); then compounds 2 and 1 (each within the scatter of the next).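

In this assay, for the compounds shown here, compound 4 is the first case in which the change removes the saturated chain carbon itself and puts methylcarbamoyl directly on the saturated ring carbon, and the reading still falls clearly when that group replaces either ring-bearing side chain: a number 0.79 log units lower from compound 1 to compound 4 (beyond the scatter), and a number 0.61 log units lower from compound 2 to compound 4 (beyond the scatter). Against the open-chain side group the same change gives a number 0.01 log units higher from compound 3 to compound 4 (within the scatter), so the two compounds cannot be told apart in this assay even though one keeps the chain carbon and the other does not. Among these four compounds, the side groups carrying a hydrogen on nitrogen, in compound 3 and compound 4, lie below the two ring-bearing groups of compound 1 and compound 2, and none of the four goes against this.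

Nothing shown gives a reason for these steps. Still open, from the compounds shown here alone, is whether the chain carbon matters apart from the amide hydrogen, which an acetamidomethyl group on the same saturated ring carbon could address, and how a dimethylcarboxamide or a carboxylic acid there would read.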